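This account rests on a few compounds, and the source may have more. Where it says the series, first, only, none or still open, it means among the compounds named here.

Measured compounds:
compound 1 `COc1cc(-c2cc(C(=O)/C=C/c3ccc(Cl)cc3)nc3cc(-c4ccccc4)nn23)cc(OC)c1OC` – 19500 nM
compound 2 `COc1cc(-c2cc(C(=O)/C=C/c3ccccc3)nc3cc(-c4ccccc4)nn23)cc(OC)c1OC` – 16300 nM
compound 3 `COc1ccc(-c2cc(/C=C/C(=O)c3ccccc3)nc3cc(-c4ccccc4)nn23)cc1OC` – 10000 nM

In a functional assay on DU-145 cells (Homo sapiens) for antiproliferative activity, read by MTT assay, with a stated time of 24 h (a lower number here means a stronger inhibitor, a higher number a weaker inhibitor), compound 2 gives 16300 nM, and compound 1 gives 19500 nM; the step between them, a 1.2-fold higher number from compound 2 to compound 1 (0.08 log units; within the scatter), comes with the change (chloro in place of hydrogen on an aromatic carbon). Compound 3 gives 10000 nM; its difference from compound 2 is not broken down here, so the two cores are only compared by their values, which lie within the scatter of each other.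

Compound 4 `COc1ccc(-c2cc(/C=C/C(=O)c3ccc(Cl)cc3)nc3cc(-c4ccccc4)nn23)cc1OC` is not yet measured. It differs from compound 3 by chloro in place of hydrogen on an aromatic carbon, the same change as from compound 2 to compound 1. Because that step, a 1.2-fold higher number from compound 2 to compound 1 (0.08 log units; within the scatter), was within the scatter, a step of similar size is expected: a 1.2-fold higher number from compound 3 to compound 4 (0.08 log units; within the scatter). The estimate for compound 4 is 12000 nM, within 5000 nM to 28000 nM.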

Compound 4, half-maximal inhibitory concentration: 21300 nM
Estimate against measurement, compound 4: 1.8-fold (0.25 log units) below; the measured number falls inside the stated range.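

In this assay, chloro in place of hydrogen on the aromatic carbon gives a 2.1-fold higher number from compound 3 to compound 4 (0.33 log units; beyond the scatter), a modest step, and set beside the same change on the other core, the two steps cannot be told apart: the same change on two cores in this assay, a 1.2-fold higher number (0.08 log units; within the scatter) from compound 2 to compound 1 and a 2.1-fold higher number (0.33 log units; beyond the scatter) from compound 3 to compound 4, 1.8-fold (0.25 log units) apart, within the scatter of two such steps. The data therefore give no ground for treating this change differently on the two cores. Among these compounds, this does not fix a single size for the step: only one pair per core is at hand, and a 1.2-fold higher number from compound 2 to compound 1 (0.08 log units; within the scatter) stays within the scatter.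

On these data alone, it remains open whether an amine or a carboxylic acid in place of the chloro would behave alike on both cores. The two cores also differ from each other in more than one place, and no single one of those differences can be read from these compounds.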